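Series notes: trifluoromethyl in place of isopropyl on oxygen

A few compounds are considered here, and "the series" means these few. Any claim that something is new, unique, unknown or untested is made for them only; others in the source may bear on it.

Compound 1 `COc1cc(-n2ncnc2-c2cccc([N+](=O)[O-])c2)cc(OC)c1OC`, compound 2 `COc1cc(-n2ncnc2-c2ccc(OC(C)C)cc2)cc(OC)c1OC` and compound 3 `COc1cc(-c2ncnn2-c2cccc(N)c2)cc(OC)c1OC` have been tested in a functional assay on A549 cells (Homo sapiens) for antiproliferative activity, read by MTT assay, with a stated time of 72 h; on this read-out higher numbers stand for weaker inhibition and lower numbers for stronger inhibition. In this assay compound 1 gives only a limit, > 10000 nM. For compound 2 the read-out in this assay is likewise a limit, > 10000 nM. Compound 3 also returns a limit in this assay, > 10000 nM. For the measured compounds named here, every value so far therefore sits at the limit of > 10000 nM in this assay, at which 3 of the 3 values shown sit; compound 2 stands with the others, and none of the three is separated from the rest. Going by the values given here, no step between measured compounds is drawn: no two of them differ in one place.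

Compound 4 `COc1cc(-n2ncnc2-c2ccc(OC(F)(F)F)cc2)cc(OC)c1OC` is not yet measured. It differs from compound 2 by trifluoromethyl in place of isopropyl on an oxygen on an aromatic ring. The three results at hand give no ground to expect movement off the limit. With every measured compound at the limit, no step beyond the scatter is expected in this assay, and the step from compound 2 to compound 4 is estimated as a step that the limit leaves unreadable from compound 2 to compound 4. Compound 4 is expected to give 20000 nM, with a range from 5000 nM to 100000 nM, and most probably to be reported again as a limit rather than as a number.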

Compound 4, half-maximal inhibitory concentration: > 10000 nM
Compound 4: no number, only a limit; the forecaster's own chance of this, stated with the estimate: 80%; the middle value is on the limit's open side.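

For the compounds shown here, compound 2 and compound 4 both return only a limit in this assay and no step between them can be read. Left open is whether any change on the shared core brings a value off the limit in this assay and how trifluoromethyl and isopropyl on the oxygen compare once a number can be read.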